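The source may report more compounds than this note shows. Statements on the series, on what has been measured and on what is new or still open speak of the compounds shown alone.

Three compounds share one core and differ only in the group attached to a double-bonded ring carbon. Compound 1 `CCOC1=C(C(=O)c2ccccc2)C(c2ccc(Br)cc2)N(CCCn2ccnc2)C1=O` gives 35300 nM in a functional assay on A549 cells (Homo sapiens) for antiproliferative activity, read by MTT assay, with a stated time of 72 h; on this read-out lower numbers stand for stronger inhibition and higher numbers for weaker inhibition. Compound 2 `CC(C)OC1=C(C(=O)c2ccccc2)C(c2ccc(Br)cc2)N(CCCn2ccnc2)C1=O` gives 8720 nM in this assay. Compound 3 `O=C(C1=C(Nc2ccc(OC(F)(F)F)cc2)C(=O)N(CCCn2ccnc2)C1c1ccc(Br)cc1)c1ccccc1` gives 20800 nM in this assay, which places it second highest of the three numbers, with compound 1 nearest and compound 2 furthest. The step of a 1.7-fold lower number from compound 1 to compound 3 (0.23 log units; within the scatter) lies within the scatter, whereas the step of a 2.4-fold higher number from compound 2 to compound 3 (0.38 log units; beyond the scatter) and the step of a 4.0-fold lower number from compound 1 to compound 2 (0.61 log units; beyond the scatter) are modest but beyond it.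

Compound 4 `O=C(C1=C(NCc2ccccc2)C(=O)N(CCCn2ccnc2)C1c1ccc(Br)cc1)c1ccccc1` has not yet been measured. It differs from compound 3 in one place: benzyl in place of 4-(trifluoromethoxy)phenyl on an amine nitrogen. Within the data shown here, none of the measured steps alters a group on that amine nitrogen; each swaps the whole group on the double-bonded ring carbon, and those swaps moved the numbers only modestly. On that basis a step of no more than similar size is expected, with no clear direction, so the expected step of a 1.0-fold lower number from compound 3 to compound 4 (0.02 log units; within the scatter) is small. Compound 4 is estimated at 20000 nM in this assay, within a range from 6000 nM to 60000 nM.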

Compound 4, half-maximal inhibitory concentration: 52800 nM
For compound 4 the middle estimate is 2.6-fold (0.42 log units) below the measured one; the range from low to high includes it.
By their numbers in this assay, from the lowest: compound 2; then compounds 3, 1 and 4 (each within the scatter of the next, the first and the last beyond it).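

Among these compounds, this is the first change made on the amine nitrogen itself rather than to the whole group on the double-bonded ring carbon. In this assay, replacing 4-(trifluoromethoxy)phenyl with benzyl gives a 2.5-fold higher number from compound 3 to compound 4 (0.40 log units; beyond the scatter) and so shows that the group on this nitrogen can shift the number modestly. Benzylamino gives a 1.5-fold higher number from compound 1 to compound 4 (0.17 log units; within the scatter) when set against ethoxy and a 6.1-fold higher number from compound 2 to compound 4 (0.78 log units; beyond the scatter) when set against isopropoxy, and nothing shown gives a reason for these steps.

Benzyl differs from 4-(trifluoromethoxy)phenyl both in its extra carbon link and in lacking the trifluoromethoxy group, so a plain phenyl on the nitrogen would be needed to separate the two changes. On these data alone, it also stays open whether a longer ether chain, such as butoxy, would give a lower number than isopropoxy does.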